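The compounds below may be only part of what the source reports. "The series", "measured", "known", "first", "only" and "open" are said of these compounds alone.

Measured compounds:
compound 1 `CSc1ccc(-c2nc3c(=O)n(C)c(=O)n(C)c3[nH]2)cc1`, 2 nM
compound 2 `Cc1cccc(-c2nc3c(=O)n(C)c(=O)n(C)c3[nH]2)c1`, 13 nM
compound 3 `Cn1c(=O)c2nc(-c3cccc(O)c3)[nH]c2n(C)c1=O`, 6 nM

In an assay for binding affinity to adenosine receptor A1 (Bos taurus) (on this read-out lower numbers stand for stronger inhibition and higher numbers for weaker inhibition), compound 1 stands with the lowest number of the three, compound 3 the nearest to it and compound 2 the furthest, both gaps beyond the scatter. The step to the new compound 4 `Cn1c(=O)c2nc(-c3ccc([N+](=O)[O-])cc3)[nH]c2n(C)c1=O` is nitro in place of methylsulfanyl on an aromatic carbon. Within the data shown here, only one measured step exists here, a 2.2-fold lower number from compound 2 to compound 3 (0.34 log units; beyond the scatter), a hydroxy in place of methyl on an aromatic carbon; it touches a different position of the same ring and a different pair of groups, so it bears on the present change only loosely, showing that a small exchange on this ring moved this assay by a modest amount. Among the measured compounds shown here, no measured step shows a nitro anywhere, and no step shows what leaves a methylsulfanyl. The expectation therefore rests on the shared core and the position alone, and compound 4 is expected to show a modest step to a higher number, a 4.0-fold higher number from compound 1 to compound 4 (0.60 log units; beyond the scatter), within a wide range. The estimate for compound 4 is 8 nM, between 2 nM and 30 nM.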

Compound 4, half-maximal inhibitory concentration: 8 nM
For compound 4 middle estimate and measured number coincide at the digits printed, and the stated range covers the measured number.
By their numbers in this assay, from the lowest: compound 1; then compounds 3, 4 and 2 (each within the scatter of the next, the first and the last beyond it).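

In this assay, among these compounds, the exchange of methylsulfanyl for nitro on the aromatic carbon para to a large group gives a 4.0-fold higher number from compound 1 to compound 4 (0.60 log units; beyond the scatter) as the first measured step at this position. The step is modest, and compound 4 still reads 8 nM in this assay, so a nitro is accepted at this position with only a modest loss against methylsulfanyl. No measurement shown here accounts for the size of this step.

Going by these compounds, with only these two groups at this position, it remains open how an amine, a carboxylic acid or a longer chain such as ethylsulfanyl would read there in this assay for the same core. Also open, on these data alone, is whether a nitro would give a similar step at the ring position that carries the methyl in compound 2 and the hydroxy in compound 3.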